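The compounds below may be only part of what the source reports. "The series", "measured", "known", "first", "only" and "open" are said of these compounds alone.

The measured compounds and their numbers in an assay on membranes from HeLa cells for displacement of a labelled ligand from adenosine receptor A3 (Homo sapiens), read by scintillation counting, with a stated time of 180 min, tested at 1 uM; on this read-out lower numbers stand for less inhibition and higher numbers for more inhibition at the one concentration tested (going by the name of the read-out):

Compound 1, `CCCOC(=O)C1=C(C)NC(=O)NC1c1ccsc1`, gives 6%.
Compound 2, `CC1=C(C(=O)OCc2ccccc2)C(c2ccsc2)NC(=O)N1`, gives 25%.
Compound 3, `CCC(C)OC(=O)C1=C(C)NC(=O)NC1c1ccoc1`, gives 11%.

Compound 3 stands second highest of these three numbers. Its nearest neighbour is compound 1, whose value in this assay of 6% lies within the usual scatter of the value of compound 3; its furthest is compound 2, whose 25% lies beyond it. Going by the values given here, the only single-point step among the measured compounds is a number 19 percentage points higher from compound 1 to compound 2 (beyond the scatter), and it concerns the ester part, not the ring on the saturated ring carbon, so it does not bear directly on the next change.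

Compound 4, `CCC(C)OC(=O)C1=C(C)NC(=O)NC1c1ccsc1`, differs from compound 3 in one place: thiophen-3-yl in place of furan-3-yl on a saturated ring carbon. Among the compounds with values here, no measured step isolates this swap. Compound 1 carries the thiophene ring and compound 3 the furan ring, with a different ester each, and their two numbers sit within the scatter of one another. The step of a number 1 percentage points lower from compound 3 to compound 4 (within the scatter) is therefore expected to be small, not beyond the scatter. Compound 4 is estimated at 10%, within a range of 0% to 25%.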

Compound 4, a percentage reported as inhibition, at one concentration (the size of the read-out at that concentration, not a potency): 7%
The estimate for compound 4 lay 3 percentage points above the measured number; measured number inside the range.
By their numbers in this assay, from the lowest: compounds 1, 4 and 3 (each within the scatter of the next); then compound 2.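

With the sec-butyl ester in place, a number 4 percentage points lower from compound 3 to compound 4 (within the scatter) follows when thiophen-3-yl replaces furan-3-yl on the saturated ring carbon in this assay, so these two rings cannot be told apart here. On the ester side, sec-butyl in place of benzyl on the oxygen gives a number 18 percentage points lower from compound 2 to compound 4 (beyond the scatter), whereas methyl in place of hydrogen on the saturated chain carbon gives only a number 1 percentage points higher from compound 1 to compound 4 (within the scatter), so among these compounds only the step involving benzyl lies beyond the scatter. No supporting measurement is available to explain any of these results.

The compounds shown leave open whether a phenyl ring or an amine on a short chain at the saturated ring carbon would shift the number. They also leave open whether furan-3-yl and thiophen-3-yl would still match alongside the benzyl ester.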